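A few compounds are considered here, and "the series" means these few. Any claim that something is new, unique, unknown or untested is made for them only; others in the source may bear on it.

Working notes on the series. All three compounds share one core and differ only in the group carried on the ring nitrogen of that core. In a functional assay on Chem-1 cells for antagonist activity at C-X-C chemokine receptor type 4 (Homo sapiens), read by calcium flux (a lower number here means a stronger inhibitor, a higher number a weaker inhibitor), compound 1 `NCCCCN(C[C@@H]1CN(C(=O)c2ccco2)CCN1)[C@H]1CCCc2cccnc21` gives 35 nM. In this assay, within the data shown here, compound 2 `NCCCCN(C[C@H]1CN(S(=O)(=O)c2ccc3ccccc3c2)CCN1)[C@H]1CCCc2cccnc21` gives 71 nM, the higher of the two numbers so far; compound 1 sits a step lower, and that gap lies beyond the scatter. Compound 3 `NCCCCN(C[C@H]1CN(S(=O)(=O)c2cc3ccccc3s2)CCN1)[C@H]1CCCc2cccnc21` differs from compound 2 by 1-benzothiophen-2-yl in place of naphthalen-2-yl on a sulfonyl sulfur. Among the measured compounds shown here, no measured pair isolates a swap of this kind on the sulfonyl sulfur, so the data give no direction for it. The expectation is that the step from compound 2 to compound 3 in this assay will be small, a 1.2-fold lower number from compound 2 to compound 3 (0.07 log units; within the scatter), and not clearly beyond the scatter. On that basis compound 3 is estimated at 60 nM in this assay, with a range from 25 nM to 150 nM.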

Compound 3, half-maximal inhibitory concentration: 39 nM
Estimate against measurement, compound 3: 1.5-fold (0.19 log units) above, within the range that was stated.
By their numbers in this assay, from the lowest: compounds 1, 3 and 2 (each within the scatter of the next, the first and the last beyond it).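

In this assay, among these compounds, the change to 1-benzothiophen-2-yl in place of naphthalen-2-yl gives a 1.8-fold lower number from compound 2 to compound 3 (0.26 log units; within the scatter) and is the first step read at this position, on a sulfonyl sulfur whose other neighbour is the sulfonamide nitrogen in a ring. For this one pair, a five-membered aromatic ring with one hetero atom in place of a six-membered aromatic ring of carbon only, together with the loss of one heavy atom, leaves no difference that can be separated from the scatter. The data give no explanation for this result. Still open, on these data alone, is whether a single phenyl ring, or a 1-benzothiophen-2-yl group carrying an amine or a carboxylic acid, would hold the number in the same region. Also open, as far as these compounds go, is how the sulfonyl link compares with the carbonyl of compound 1, since that compound also carries a different aromatic group.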